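The compounds below may be only part of what the source reports. "The series", "measured", "known", "first", "only" and "open" are said of these compounds alone.

Working notes on the series, step from compound 2 to compound 4.

In a functional assay on HUVEC cells (Homo sapiens) for antiproliferative activity, read by MTT assay, with a stated time of 24 h (a higher number here means a weaker inhibitor, a lower number a stronger inhibitor), compound 2 `COc1cccc(C(=O)Oc2ccc3c(=O)c(-c4cc(OC)c(OC)cc4OC)coc3c2)c1` gives > 10000 nM, a limit of the assay rather than a number. Compound 1 `COc1cc(OC)c(-c2coc3cc(OCc4ccccc4)ccc3c2=O)cc1OC` gives 9750 nM in this assay. Compound 3 `COc1cc(OC)c(-c2coc3cc(OCc4ccc([N+](=O)[O-])cc4)ccc3c2=O)cc1OC` gives > 10000 nM, again a limit. The picture is the limit of > 10000 nM in this assay, at which 2 of the 3 values shown sit, and compound 1 lies close to it.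

Compound 4 `COc1cc(OC)c(-c2coc3cc(OCc4ccccc4C(F)(F)F)ccc3c2=O)cc1OC` is unmeasured. Relative to compound 2 the change is 2-(trifluoromethyl)benzyl in place of (3-methoxyphenyl)carbonyl on an oxygen on an aromatic ring.

Measured steps that bear on it: an at least 1.0-fold higher number from compound 1 to compound 2 (0.01 log units; that floor lies within the scatter) runs between a benzyl ether and the (3-methoxyphenyl)carbonyl ester; an at least 1.0-fold higher number from compound 1 to compound 3 (0.01 log units; that floor lies within the scatter) adds a nitro to the benzyl; a step that the two limits leave unreadable from compound 2 to compound 3 joins two limits. Among the measured compounds shown here, no readable step leaves the scatter, and no step joins two values that are both numbers.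

Compound 4 returns to a benzyl ether, here carrying a trifluoromethyl. Compound 1, the plain benzyl ether, holds at 9750 nM. Compound 3, the benzyl ether with a nitro, sits at the limit > 10000 nM. Compound 4 is therefore expected to remain in the same region, the step of a number no higher from compound 2 to compound 4 (the limit leaves the size open) being expected to stay within the scatter. The estimate for compound 4 in this assay is 10000 nM, with a range from 4000 nM to 30000 nM, and a fair chance that only a limit is reported.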

Compound 4, half-maximal inhibitory concentration: > 10000 nM
Compound 4: no number, only a limit (the forecaster's own chance of this, stated with the estimate: 60%); the middle value sits exactly at the limit.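

On the oxygen on an aromatic ring, a second substituted benzyl ether now stands beside the nitro one, and in this assay adding the trifluoromethyl to the plain benzyl ether gives an at least 1.0-fold higher number from compound 1 to compound 4 (0.01 log units; that floor lies within the scatter). The other two new steps each join two limits and cannot be read, so the 2-(trifluoromethyl)benzyl ether, the 4-nitrobenzyl ether and the (3-methoxyphenyl)carbonyl ester cannot be placed in any order. The result adds no readable difference at this position, and the set now gathers at one ceiling, which hides any difference among those three compounds: the limit of > 10000 nM in this assay, at which 3 of the 4 values shown sit.

Only compound 1 carries a number, 9750 nM. The compounds shown therefore give no value from which a real step at this position could be measured, and whether any group on this oxygen can move the number clearly away from the limit stays open. Also open, from the compounds shown here alone, is what a group of another kind would do in place of the benzyl and the ester, such as a longer chain ending in an amine, a carboxylic acid, or the free hydroxyl itself.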